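Trimming the side chain on a furan-benzimidazole core

The source may report more compounds than this note shows. Statements on the series, on what has been measured and on what is new or still open speak of the compounds shown alone.

Three compounds share the core of compound 1 `N=C1N=C(n2c(-c3ccco3)nc3ccccc32)CN1` and have been tested in a functional assay on HepG2 cells (Homo sapiens) for cytotoxicity, read by sulforhodamine B assay, with a stated time of 48 h; on this read-out lower numbers stand for stronger inhibition and higher numbers for weaker inhibition. Compound 1 gives 63500 nM, compound 2 `N=C(Cn1c(-c2ccco2)nc2ccccc21)NN` gives 74500 nM, and compound 3 `CCOC(=O)CSc1nnc(Cn2c(-c3ccco3)nc3ccccc32)s1` gives 62100 nM. Compound 2 sits alongside the other two, within the scatter of both. Within the data shown here, the only single-point step measured, a 1.2-fold higher number from compound 1 to compound 2 (0.07 log units; within the scatter), stayed within the scatter. Compound 4 `N#CCn1c(-c2ccco2)nc2ccccc21` differs from compound 2 by a group of 2 heavy atoms (1 carbon, 1 nitrogen; no ring) in place of a group of 4 heavy atoms (1 carbon, 3 nitrogen; no ring), on a saturated chain carbon bound to an aromatic nitrogen, a swap of one side chain for another on the same carbon. With only a within-scatter step as precedent, no shift beyond the scatter is expected in this assay, so compound 4 is expected to show a 1.1-fold lower number from compound 2 to compound 4 (0.03 log units; within the scatter), giving an estimate of 70000 nM with a range from 35000 nM to 140000 nM.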

Compound 4, half-maximal inhibitory concentration: 88100 nM
Estimate against measurement, compound 4: 1.3-fold (0.10 log units) below, within the range that was stated.
By their numbers in this assay, from the lowest: compounds 3, 1, 2 and 4 (each within the scatter of the next).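

In this assay, putting cyano, with 0 hydrogen-bond donors, on the saturated chain carbon bound to an aromatic nitrogen gives a 1.2-fold higher number from compound 2 to compound 4 (0.07 log units; within the scatter), and the step from the ring-bearing side chain gives a 1.4-fold higher number from compound 1 to compound 4 (0.14 log units; within the scatter). Losing the hydrogen-bond donors and the ring of the side chain therefore moved the number by no more than the scatter. Nothing available explains this result. On these data alone, whether an amine, a carboxylic acid or a longer chain on that carbon would produce a step beyond the scatter remains open.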